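This account rests on a few compounds, and the source may have more. Where it says the series, first, only, none or still open, it means among the compounds named here.

Series notes, T47D functional series.

Compound 1, `Oc1ccc(-c2cc(-c3ccccc3F)cc(-c3cccc(O)c3)n2)cc1`: in a functional assay on T47D cells (Homo sapiens) for inhibition (a lower number here means a stronger inhibitor, a higher number a weaker inhibitor), compound 1 gives 6370 nM.
Compound 2, `Oc1ccc(-c2cc(-c3ccccc3F)cc(-c3ccc(O)cc3)n2)cc1`: in this assay compound 2 gives 15100 nM.
Compound 3, `Oc1cccc(-c2cc(-c3ccccc3C(F)(F)F)cc(-c3ccccc3O)n2)c1`: in this assay compound 3 gives 5680 nM.

From compound 1 to compound 2 the change is 4-hydroxyphenyl in place of 3-hydroxyphenyl on an aromatic carbon, and the step is a 2.4-fold higher number from compound 1 to compound 2 (0.37 log units; beyond the scatter). Compound 3 and compound 1 lie within the scatter of each other; compound 3 and compound 2 differ beyond it, compound 2 giving the higher number. The difference between the core of compound 1 and the core of compound 3 is not broken down here.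

Compound 4, `Oc1ccc(-c2cc(-c3ccccc3C(F)(F)F)cc(-c3ccccc3O)n2)cc1`, is not yet measured. From compound 3 to compound 4 the change is 4-hydroxyphenyl in place of 3-hydroxyphenyl on an aromatic carbon. This is the same kind of change as from compound 1 to compound 2, not the same: in compound 3 the place is meta to a 2-(trifluoromethyl)phenyl group and meta to a 2-hydroxyphenyl group, whereas in compound 1 it is meta to a 2-fluorophenyl group and meta to a 4-hydroxyphenyl group. For the measured compounds named here, only one earlier instance exists, so the expectation rests on it alone: in this assay compound 4 is expected to show a 2.3-fold higher number from compound 3 to compound 4 (0.36 log units; beyond the scatter), about the size of a 2.4-fold higher number from compound 1 to compound 2 (0.37 log units; beyond the scatter). The estimate for compound 4 is 13000 nM, expected between 6500 nM and 28000 nM.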

Compound 4, half-maximal inhibitory concentration: 7180 nM
For compound 4 the middle estimate is 1.8-fold (0.26 log units) above the measured one, and the stated range covers the measured number.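

In this assay, 4-hydroxyphenyl in place of 3-hydroxyphenyl gives a 1.3-fold higher number from compound 3 to compound 4 (0.10 log units; within the scatter), so on this core the step cannot be told apart from no change. The step on the core of compound 1 lay beyond the scatter and this one does not, yet the two steps themselves cannot be told apart: the same change on two cores in this assay, a 2.4-fold higher number (0.37 log units; beyond the scatter) from compound 1 to compound 2 and a 1.3-fold higher number (0.10 log units; within the scatter) from compound 3 to compound 4, 1.9-fold (0.27 log units) apart, within the scatter of two such steps. For the compounds shown here, this shows that the two results are compatible with one shared step size, but it does not show that the change carries over at a fixed size, since there are only two instances and the cores of compound 1 and compound 3 differ in more than one place.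

The compounds shown leave open how the step would read on further cores, including one bearing a methyl or a chlorine in place of the fluorine or trifluoromethyl group. They also leave open what an amine or a carboxylic acid in place of the hydroxyl on this phenyl ring would give in this assay.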